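Series notes: ring-carbon propyl on the shared core

This account rests on a few compounds, and the source may have more. Where it says the series, first, only, none or still open, it means among the compounds named here.

Measured compounds in an assay on brain for displacement of a labelled ligand from Sigma non-opioid intracellular receptor 1 (Cavia porcellus); on this read-out higher numbers stand for weaker inhibition and lower numbers for stronger inhibition:
- compound 1 `NCC[C@@H]1CCO[C@H](c2ccccc2)O1`: in this assay compound 1 gives > 10000 nM, a limit of the assay and not a number.
- compound 2 `NCCC1CCOC(c2ccccc2)O1`: in this assay compound 2 gives > 10000 nM, again a limit.
- compound 3 `c1ccc(CNCC[C@@H]2CCO[C@H](c3ccccc3)O2)cc1`: in this assay compound 3 gives 6 nM.

Compound 1 stands at a limit only, and the same limit holds for one further value shown. The step that the two limits leave unreadable from compound 1 to compound 2 cannot be read because of the limit of > 10000 nM in this assay, at which 2 of the 3 values shown sit; the two differ as drawn only in that (the fact that one of compounds 1 and 2 is drawn with a defined configuration and the other without, at the place where they differ). Among the measured compounds shown here, the step of an at least 1600-fold lower number from compound 1 to compound 3 (3.22 log units; beyond the scatter) is the one readable step in the set and is large, the sole change being benzyl in place of hydrogen on an amine nitrogen.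

Compound 4 `CCC[C@@]1(c2ccccc2)OCC[C@@H](CCN)O1` differs from compound 1 in one place: propyl in place of hydrogen on a saturated ring carbon. The group enters on the ring atom between two ring oxygen atoms. Neither measured step touches this place: one concerns drawn configuration, the other the amine nitrogen. So no measured step bears on the change, and the amine of compound 4 stays unsubstituted as in compound 1.

With nothing to read from, compound 4 is expected to remain near the limit of compound 1, a step of a number no higher from compound 1 to compound 4 (the limit leaves the size open) of no readable size. The estimate for compound 4 in this assay is 10000 nM, within 3000 nM to 30000 nM.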

Compound 4, inhibition constant: > 10000 nM
Compound 4 ended at the assay's limit; the forecaster's own chance of this, stated with the estimate: 60%; the middle value sits exactly at the limit.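

The step from compound 1 to compound 4 cannot be read, because both compounds sit at the same limit of the assay, which is a limit and not a number: the limit of > 10000 nM in this assay, at which 3 of the 4 values shown sit.

The compounds shown leave open whether propyl in place of hydrogen on a saturated ring carbon changes the read-out at all, either with the unsubstituted amine or with the benzyl-bearing amine of compound 3.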